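A few compounds are considered here, and "the series" means these few. Any claim that something is new, unique, unknown or untested is made for them only; others in the source may bear on it.

Measured in a functional assay on HepG2 cells (Homo sapiens) for antiproliferative activity, read by MTT assay, with a stated time of 72 h; a higher number here means a weaker inhibitor, a lower number a stronger inhibitor:
- compound 1 `NC1=NC2(CCOCC2)N(OCCCOc2ccccc2Cl)C(N)=N1`: 1750 nM
- compound 2 `NC1=NC2(CCOCC2)N(OCCCOc2ccc(Cl)c(Cl)c2)C(N)=N1`: 380 nM
- compound 3 `NC1=NC2(CCOCC2)N(OCCCOc2ccccc2Br)C(N)=N1`: 860 nM

Compound 3 holds the second highest of these three numbers, at 860 nM, with a 2.0-fold lower number from compound 1 to compound 3 (0.31 log units; beyond the scatter) and a 2.3-fold higher number from compound 2 to compound 3 (0.35 log units; beyond the scatter). The next compound, compound 4 `NC1=NC2(CCOCC2)N(OCCCOc2cccc(Br)c2)C(N)=N1`, has not yet been measured. It differs only in the aryl group: 3-bromophenyl in place of 2-bromophenyl on an oxygen on a saturated carbon. In words, it has 3-bromophenyl in place of 2-bromophenyl on an oxygen on a saturated carbon.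

For the measured compounds named here, no measured pair isolates this change. The step of a 2.0-fold lower number from compound 1 to compound 3 (0.31 log units; beyond the scatter) swaps one halogen for another and says little about where the halogen sits. Compound 2, with 3,4-dichlorophenyl, has the lowest number at 380 nM. The two steps involving that group are a 4.6-fold lower number from compound 1 to compound 2 (0.66 log units; beyond the scatter) and a 2.3-fold higher number from compound 2 to compound 3 (0.35 log units; beyond the scatter). Both are modest, and both change more than the place of a single halogen, so they offer only weak guidance. They suggest a small move towards a lower number, smaller than either step and possibly within the scatter. The expected change is a 1.4-fold lower number from compound 3 to compound 4 (0.16 log units; within the scatter). For compound 4 the estimated value is 600 nM, with an expected range from 250 nM to 1400 nM.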

Compound 4, half-maximal inhibitory concentration: 320 nM
Beside the measured number, compound 4's estimate is 1.9-fold (0.27 log units) above it; the measured number falls inside the stated range.
By their numbers in this assay, from the lowest: compounds 4 and 2 (each within the scatter of the next); then compound 3; then compound 1.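

For the compounds shown here, replacing 2-bromophenyl with 3-bromophenyl keeps the same atoms joined differently, so this step gives the first isolated reading of how the halogen's place on the aryl group matters: a 2.7-fold lower number from compound 3 to compound 4 (0.43 log units; beyond the scatter) in this assay is a modest change, and it is larger than the one for bromo in place of chloro, a 2.0-fold lower number from compound 1 to compound 3 (0.31 log units; beyond the scatter). The 3-bromophenyl and 3,4-dichlorophenyl groups cannot be told apart here, with a 1.2-fold lower number from compound 2 to compound 4 (0.07 log units; within the scatter) as their step, so a single bromine in this form does as well as the two chlorines of compound 2. The largest step among these compounds, a 5.5-fold lower number from compound 1 to compound 4 (0.74 log units; beyond the scatter), changes both the halogen and its place, so it cannot be credited to either change alone.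

No measurement shown explains why the place of the bromine changes the number in this assay. From the compounds shown here alone, it remains open whether chloro responds to the same change of place as bromo, and how an amine or a carboxylic acid on the aryl group, or a longer chain carrying the bromophenoxy group, would compare.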